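Swapping a fluorophenyl for a nitrophenyl in a piperidinone sulfonamide

This account rests on a few compounds, and the source may have more. Where it says the series, first, only, none or still open, it means among the compounds named here.

This account concerns a small set of bis-benzylidene piperidinone sulfonamides examined in an ADME assay on L02 cells (Homo sapiens) for cytotoxicity, read by MTT assay, with a stated time of 24 h; on this read-out lower numbers stand for stronger inhibition and higher numbers for weaker inhibition. Compound 1 `O=C1/C(=C/c2ccccc2F)CN(S(=O)(=O)c2ccc(F)cc2)C/C1=C\c1ccccc1F` carries a fluorine-bearing sulfonyl arene and two identical fluorophenyl arms; in this assay compound 1 gives 19100 nM. Compound 2 `O=C1/C(=C/c2cccc([N+](=O)[O-])c2)CN(S(=O)(=O)c2ccc(F)cc2)C/C1=C\c1ccccc1F` differs from it in one place, described as 3-nitrophenyl in place of 2-fluorophenyl on a double-bonded chain carbon bound to a double-bonded ring carbon, and in this assay compound 2 gives 17000 nM. The step of a 1.1-fold lower number from compound 1 to compound 2 (0.05 log units; within the scatter) is therefore small.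

Compound 3 `COc1cc(/C=C2\CN(S(=O)(=O)c3ccc(NC(C)=O)cc3)C/C(=C\c3ccccc3F)C2=O)cc(OC)c1OC` has a different core, with an acetamido-substituted sulfonyl arene and a trimethoxyphenyl arm; how this core differs from that of compound 1 is not broken down here. In this assay compound 3 gives 14000 nM, a number that sits within the scatter of both compound 1 and compound 2, so no ordering among the three can be claimed.

Compound 4 `COc1cc(/C=C2\CN(S(=O)(=O)c3ccc(NC(C)=O)cc3)C/C(=C\c3cccc([N+](=O)[O-])c3)C2=O)cc(OC)c1OC` is made from compound 3 by the change (3-nitrophenyl in place of 2-fluorophenyl on a double-bonded chain carbon bound to a double-bonded ring carbon), which is the same change, at the same place, as that taken from compound 1 to compound 2. Because a 1.1-fold lower number from compound 1 to compound 2 (0.05 log units; within the scatter) was within the scatter, the step of a 1.1-fold lower number from compound 3 to compound 4 (0.05 log units; within the scatter) is expected to be similarly small. On that basis the value of compound 4 in this assay is estimated at 12500 nM, most likely between 6000 nM and 26000 nM.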

Compound 4, half-maximal inhibitory concentration: 15600 nM
The estimate for compound 4 lay 1.2-fold (0.10 log units) below the measured number; the range from low to high includes it.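

In this assay, the exchange of 2-fluorophenyl for 3-nitrophenyl gives a 1.1-fold higher number from compound 3 to compound 4 (0.05 log units; within the scatter), so on this second core the number again stays inside the usual scatter. Set beside the earlier step, the two results do not differ: the same change on two cores in this assay, a 1.1-fold lower number (0.05 log units; within the scatter) from compound 1 to compound 2 and a 1.1-fold higher number (0.05 log units; within the scatter) from compound 3 to compound 4, 1.3-fold (0.10 log units) apart, within the scatter of two such steps. This shows that, in these two pairs and at this one place, on a double-bonded chain carbon bound to a double-bonded ring carbon, the change carries from one core to the other as a step too small to read; it does not show a shared effect of real size, since neither step stands beyond the scatter, and two pairs say nothing about how the change would behave on any further core.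

The compounds shown leave open whether another group at this place, such as an amine, a carboxylic acid or a longer chain, would give a step beyond the scatter in either core. They also leave open whether the same exchange would remain this small on a core whose sulfonyl arene carries an amine in place of the fluorine or the acetamido group.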